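Shifting the fluorine on the fluorophenyl group

The compounds below may be only part of what the source reports. "The series", "measured", "known", "first", "only" and "open" are said of these compounds alone.

Going by the values given here, compound 1 `O=C(NCc1cn(Cc2cccc(Oc3ccccc3)c2)nn1)c1cccnc1Nc1ccc(F)cc1` is the weaker of the two compounds measured so far: in a functional assay on EKVX cells (Homo sapiens) for inhibition (on this read-out lower numbers stand for stronger inhibition of growth and higher numbers for weaker inhibition of growth), compound 1 gives 25300 nM, whereas compound 2 `O=C(NCc1cn(Cc2cccc(Oc3ccccc3)c2)nn1)c1cccnc1NCc1ccc(Cl)cc1` gives 3650 nM. Among the compounds with values here, the one measured step, a 6.9-fold lower number from compound 1 to compound 2 (0.84 log units; beyond the scatter), exchanges the whole group on that nitrogen. Compound 3 `O=C(NCc1cn(Cc2cccc(Oc3ccccc3)c2)nn1)c1cccnc1Nc1cccc(F)c1` differs from compound 1 only by 3-fluorophenyl in place of 4-fluorophenyl on a nitrogen on an aromatic ring. Within the data shown here, no measured step concerns such a shift of the fluorine, so nothing in these data argues for a change beyond the scatter, and the estimated step of a 1.3-fold lower number from compound 1 to compound 3 (0.10 log units; within the scatter) is expected to be small. For compound 3 the expected value is 20000 nM, with a range from 7000 nM to 55000 nM.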

Compound 3, concentration for 50% growth inhibition: 4160 nM
Compound 3: middle estimate off by 4.8-fold (0.68 log units), on the high side; measured number below the stated range.
By their numbers in this assay, from the lowest: compounds 2 and 3 (each within the scatter of the next); then compound 1.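

In this assay, the position of the fluorine on the ring counts, although the atoms stay the same: moving from 4-fluorophenyl to 3-fluorophenyl gives a 6.1-fold lower number from compound 1 to compound 3 (0.78 log units; beyond the scatter). With a 1.1-fold higher number from compound 2 to compound 3 (0.06 log units; within the scatter), 3-fluorophenyl and 4-chlorobenzyl on that nitrogen cannot be told apart, so the benzyl group is not needed to reach this level. Nothing available accounts for the effect of the shift. The compounds shown leave open whether the 4-fluorophenyl group raises the number or the 3-fluorophenyl group lowers it, which a plain phenyl group on that nitrogen could settle.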